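The source may report more compounds than this note shows. Statements on the series, on what has been measured and on what is new or still open speak of the compounds shown alone.

In a functional assay on THP-1 cells (Homo sapiens) for inhibition, read by sulforhodamine B assay, with a stated time of 48 h (on this read-out lower numbers stand for stronger inhibition and higher numbers for weaker inhibition), compound 2 `COc1ccc(C(O)(Cc2ccc(C)cc2)c2cccc3ccccc23)c(OC)c1OC` gives > 20000 nM, which is a limit and not a number. Compound 1 `COc1ccc(/C(=N/O)c2cccc3ccccc23)c(OC)c1OC` gives > 20000 nM, also a limit. Compound 3 `CCOC(=O)CO/N=C(/c1ccc(OC)c(OC)c1OC)c1cccc2ccccc12` gives > 20000 nM, again a limit. The picture so far is therefore a single one: the limit of > 20000 nM in this assay, at which 3 of the 3 values shown sit.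

Compound 4 `COc1ccc(C(O)(Cc2ccc(F)cc2)c2cccc3ccccc23)c(OC)c1OC` differs from compound 2 by fluoro in place of methyl on an aromatic carbon, para to a large group, so that 4-methylbenzyl becomes 4-fluorobenzyl: fluoro in place of methyl on an aromatic carbon. Going by the values given here, the only measured step, a step that the two limits leave unreadable from compound 1 to compound 3, lies at a different place, on an oxygen, and gives no size to carry over. Among the compounds with values here, no measured step covers this exchange, so no shift in either direction beyond the usual scatter is expected in this assay, and another limit is the likeliest report. The expected change is a step that the limit leaves unreadable from compound 2 to compound 4. The estimate for compound 4 is 30000 nM, with an expected range of 12000 nM to 80000 nM.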

Compound 4, half-maximal inhibitory concentration: 5860 nM
Beside the measured number, compound 4's estimate is 5.1-fold (0.71 log units) above it; measured number below the stated range.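

Going by these compounds alone, on the aromatic carbon para to a large group, fluoro in place of methyl is the first exchange with a readable effect in this assay: there is an at least 3.4-fold lower number from compound 2 to compound 4 (0.53 log units; beyond the scatter). Compound 2 stands at a limit, so this step gives only a minimum size and not the full one. Compound 4 is the only compound shown with a true number, and the others remain at a single limit: the limit of > 20000 nM in this assay, at which 3 of the 4 values shown sit.

The data do not separate a gain from fluoro itself from a gain through the loss of methyl, and chloro, trifluoromethyl or plain hydrogen at this place would bear on that question. As far as these compounds go, the step on the oxygen cannot be read, and it remains open how an amine in place of the hydroxyl of compound 4 would read out.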